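Moving the fluorine on the urea aryl ring of compound 1

The source may report more compounds than this note shows. Statements on the series, on what has been measured and on what is new or still open speak of the compounds shown alone.

Measured so far:
- compound 1, `COc1cc(NC(C)CCCNC(=O)Nc2ccc(F)cc2)c2ncccc2c1`: 18000 nM
- compound 2, `COc1cc(NC(C)CCCNC(=O)NNC(=O)Nc2ccc(F)cc2)c2ncccc2c1`: 104000 nM
- compound 3, `COc1cc(NC(C)CCCNC(=O)NNC(=O)Nc2ccc(C(F)(F)F)cc2)c2ncccc2c1`: 18000 nM

In a functional assay on L1210 cells (Mus musculus) for inhibition, read by MTT assay, with a stated time of 72 h (a lower number here means a stronger inhibitor, a higher number a weaker inhibitor), compound 1 stands level with compound 3 at the digits recorded, and the two share the lowest number of the three; compound 2 sits furthest away, as a 5.8-fold higher number from compound 1 to compound 2 (0.76 log units; beyond the scatter) shows. Among the measured compounds shown here, the only other measured step, a 5.8-fold lower number from compound 2 to compound 3 (0.76 log units; beyond the scatter), swaps a fluoro for a trifluoromethyl on the aromatic carbon.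

Compound 4, `COc1cc(NC(C)CCCNC(=O)Nc2cccc(F)c2)c2ncccc2c1`, is compound 1 with a single rearrangement: 3-fluorophenyl in place of 4-fluorophenyl on an amide-type nitrogen. Neither measured step bears on this directly. The step from compound 1 to compound 2 rebuilds the link between the carbonyl and the aryl ring, and the step from compound 2 to compound 3 changes the identity of the substituent rather than where it sits. For the measured compounds named here, with no precedent for moving the fluorine, the expectation for compound 4 in this assay is a step near zero, within the scatter, as no change at the digits printed from compound 1 to compound 4 (within the scatter) conveys. Compound 4 is therefore estimated at 18000 nM, with a range from 7000 nM to 45000 nM.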

Compound 4, half-maximal inhibitory concentration: 19000 nM
The estimate for compound 4 lay 1.1-fold (0.02 log units) below the measured number; the range from low to high includes it.
By their numbers in this assay, from the lowest: compounds 1, 3 and 4 (each within the scatter of the next); then compound 2.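

In this assay, among the compounds shown here, exchanging 4-fluorophenyl for 3-fluorophenyl on the amide-type nitrogen gives a 1.1-fold higher number from compound 1 to compound 4 (0.02 log units; within the scatter), the first direct reading of where the fluorine sits on this ring, and between these two compounds its place makes no difference beyond the scatter. The group on that nitrogen can still matter: a 5.5-fold lower number from compound 2 to compound 4 (0.74 log units; beyond the scatter) separates compound 4 from compound 2, which carries ((4-fluorophenyl)carbamoyl)amino there. No measurement at hand explains why the fluorine's place leaves the number unchanged here.

This covers only two fluorine placements on one ring, so it cannot be taken as a rule for other groups on that ring. As far as these compounds go, whether an amine or a carboxylic acid in place of the fluorine would leave the number as unmoved remains open.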